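The source may hold more compounds than are shown below. What is called first, only, known or untested is meant among the compounds shown, and "the series" means these compounds.

In a functional assay on L1210 cells (Mus musculus) (on this read-out lower numbers stand for stronger inhibition and higher numbers for weaker inhibition), compound 1 `CC(C)(C)C#Cc1cn([C@H]2C[C@H](O)[C@@H](CO)O2)c(=O)[nH]c1=O` gives 287 ug/mL. Compound 3 `COCC#Cc1cn([C@H]2C[C@H](O)[C@@H](CO)O2)c(=O)[nH]c1=O`, which differs from it in one place, gives 254 ug/mL. Compound 2 `Cc1ccc(S(=O)(=O)OCCC#Cc2cn([C@H]3C[C@H](O)[C@@H](CO)O3)c(=O)[nH]c2=O)cc1` is reported only as a limit of the assay, > 200 ug/mL, and so carries no number for comparison. Of the two actual numbers, compound 3 stands at the low end, but compound 1 sits so close that the gap is within the scatter: the measured step of a 1.1-fold lower number from compound 1 to compound 3 (0.05 log units; within the scatter) shows that exchanging one group on the triple-bonded carbon for another did not move the read-out beyond the usual spread of repeats.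

Compound 4 `O=c1[nH]c(=O)n([C@H]2C[C@H](O)[C@@H](CO)O2)cc1C#CCO` has not yet been measured. It differs from compound 3 by hydrogen in place of methyl on an oxygen on a saturated carbon, so that the methoxy becomes a hydroxy and the methoxymethyl on the triple-bonded carbon becomes hydroxymethyl. For the measured compounds named here, the only measured step that bears on this change is a 1.1-fold lower number from compound 1 to compound 3 (0.05 log units; within the scatter), and it stayed within the scatter. Going by the values given here, nothing among the measured compounds points to a shift in either direction, so the step of a 1.0-fold lower number from compound 3 to compound 4 (0.01 log units; within the scatter) is expected to remain within the scatter. Compound 4 is therefore estimated to give about 250 ug/mL, within a range from 120 ug/mL to 500 ug/mL.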

Compound 4, concentration for 50% inhibition: > 1000 ug/mL
Compound 4 was reported as a limit; the forecaster's own chance of this, stated with the estimate: 30%; middle value at least 4.0-fold (0.60 log units) away from the limit.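

For the compounds shown here, the one earlier step, a 1.1-fold lower number from compound 1 to compound 3 (0.05 log units; within the scatter), suggested that the group on the triple-bonded carbon could be exchanged without consequence, but the hydroxy group breaks that picture. In this assay, hydrogen in place of methyl on the oxygen gives an at least 3.9-fold higher number from compound 3 to compound 4 (0.59 log units; beyond the scatter), and hydroxymethyl in place of tert-butyl gives an at least 3.4-fold higher number from compound 1 to compound 4 (0.54 log units; beyond the scatter); both steps lie beyond the scatter and point towards weaker inhibition, so the read-out does respond to what stands at this position, and losing one methyl is enough to show it. The full size of the loss remains unknown because compound 4 is reported only as a limit, not as a number: the limit of > 1000 ug/mL in this assay, at which 1 of the 4 values shown sits.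

Compound 2 is also reported only as a limit, > 200 ug/mL, so the steps to it cannot be read. As far as these compounds go, with so few numbers, it remains open whether the loss is specific to the 3-hydroxyprop-1-yn-1-yl group or would also appear with an amine or a carboxylic acid in place of the hydroxy, or with a longer chain carrying the hydroxy.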